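The source may hold more compounds than are shown below. What is called first, only, known or untested is meant among the compounds shown, and "the series" means these compounds.

Compound 1 `O=C(Nc1cc(C(F)(F)F)cc(C(F)(F)F)c1)c1nonc1O` stands highest of the three numbers in an assay on isolated protein for inhibition of mitogen-activated protein kinase kinase kinase 14 (Homo sapiens), read by ADP-Glo, with a stated time of 60 min, tested at 100 uM, in the presence of a further agent that is not named here (a higher number here means more inhibition at the concentration tested (going by the name of the read-out), a lower number less inhibition), where compound 1 gives 19.3%. Compound 2 `Cn1nnc(O)c1C(=O)Nc1cc(C(F)(F)F)cc(C(F)(F)F)c1` gives 12.1% and compound 3 `Cn1nc(O)c(C(=O)Nc2cc(C(F)(F)F)cc(C(F)(F)F)c2)n1` gives 9.1%; the step of a number 7.2 percentage points lower from compound 1 to compound 2 (within the scatter) is within the scatter, while the step of a number 10.2 percentage points lower from compound 1 to compound 3 (beyond the scatter) is a modest one beyond it, and the step of a number 3 percentage points lower from compound 2 to compound 3 (within the scatter) is within the scatter.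

Compound 4 `O=C(Nc1cccc(C(F)(F)F)c1)c1nonc1O` differs from compound 1 in one place: hydrogen in place of trifluoromethyl on an aromatic carbon. All three measured steps change the ring on the carbonyl carbon and leave the anilide ring untouched, so none of them bears directly on this change; they show only that the whole series sits at low inhibition and that swapping the hydroxy-heteroaryl ring moves the number by small amounts. With no measured guidance for the loss of a trifluoromethyl, compound 4 is expected to move by a number 7.3 percentage points lower from compound 1 to compound 4 (within the scatter), a small downward shift that may well fall within the scatter. Compound 4 is therefore estimated at 12%, with a range from 2% to 24%.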

Compound 4, a percentage reported as inhibition, at one concentration (the size of the read-out at that concentration, not a potency): 11.8%
Estimate against measurement, compound 4: 0.2 percentage points above; low and high end bracket the measured number.
By their numbers in this assay, from the lowest: compounds 3, 4, 2 and 1 (each within the scatter of the next, the first and the last beyond it).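

Taking away one trifluoromethyl group gives a number 7.5 percentage points lower from compound 1 to compound 4 (within the scatter) in this assay, so at this position on the six-membered aromatic ring, hydrogen can stand in place of trifluoromethyl without a step that clears the scatter. For the compounds shown here, the earlier compounds differed only in the ring on the carbonyl carbon, and this is the first reading of a change on the other side of the amide. No measured evidence bearing on this result is available, so the step stands here without an explanation.

The compounds shown leave open whether another group at this position, such as a chlorine atom, a methoxy group, an amine or a carboxylic acid, would move the number beyond the scatter. From the compounds shown here alone, it also remains open whether the same change would give a similar step with the hydroxy-triazole rings of compound 2 and compound 3, or what happens when the remaining trifluoromethyl group is replaced as well.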